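This account rests on a few compounds, and the source may have more. Where it says the series, first, only, none or still open, it means among the compounds named here.

In a functional assay on SK-OV-3 cells (Homo sapiens) for antiproliferative activity, read by MTT assay, with a stated time of 24 h (on this read-out higher numbers stand for weaker inhibition and lower numbers for stronger inhibition), three analogues sharing one core have been measured. Compound 1, `COc1ccc(C(=O)/C=C/c2ccc(N(c3ccccc3)c3ccccc3)cc2)c2c1C=CC(C)(C)O2`, gives > 10000 nM, which is a limit of the assay rather than a number, as noted in the limit of > 10000 nM in this assay, at which 1 of the 3 values shown sits. Compound 2, `COc1ccc(C(=O)/C=C/c2cccc([N+](=O)[O-])c2)c2c1C=CC(C)(C)O2`, gives 9720 nM, the highest of the two numbers shown. Compound 3, `COc1ccc(C(=O)/C=C/c2cccc(C(F)(F)F)c2)c2c1C=CC(C)(C)O2`, gives 9330 nM. The step of a 1.0-fold lower number from compound 2 to compound 3 (0.02 log units; within the scatter) shows that putting a trifluoromethyl in place of the nitro on an aromatic carbon left the read-out where it was. Among the compounds with values here, compound 4, `COc1ccc(C(=O)/C=C/c2ccc(Cl)c(Cl)c2)c2c1C=CC(C)(C)O2`, differs from compound 2 in one place: 3,4-dichlorophenyl in place of 3-nitrophenyl on a double-bonded chain carbon bound to a double-bonded chain carbon The only measured step that bears on this change is the one from compound 2 to compound 3, and that step lay within the scatter, so no movement beyond the scatter is expected here either, with a fair chance that the assay again returns only a limit. Compound 4 is therefore expected to give 8500 nM, between 3500 nM and 20000 nM, in this assay. The expected step of a 1.1-fold lower number from compound 2 to compound 4 (0.06 log units; within the scatter) is estimated to lie within the scatter.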

Compound 4, half-maximal inhibitory concentration: 9940 nM
For compound 4 the middle estimate is 1.2-fold (0.07 log units) below the measured one, and the stated range covers the measured number.
By their numbers in this assay, from the lowest: compounds 3, 2 and 4 (each within the scatter of the next). At a limit, above all of these: compound 1.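

The step of a 1.0-fold higher number from compound 2 to compound 4 (0.01 log units; within the scatter) shows that in this assay, the read-out also holds when the whole 3-nitrophenyl gives way to 3,4-dichlorophenyl on a double-bonded chain carbon bound to a double-bonded chain carbon. The earlier step exchanged only nitro for trifluoromethyl on an aromatic carbon, whereas this one goes from a group with 2 hydrogen-bond acceptors to a group with 0, and still the read-out stays where it was. Compound 4 returned a number and not a limit, and only one compound shown remains at the limit: the limit of > 10000 nM in this assay, at which 1 of the 4 values shown sits.

The compounds shown leave open whether any group at this place can move the read-out beyond the scatter, for example a phenyl carrying an amine or a carboxylic acid. They also leave open whether a phenyl with a single chlorine would read like 3,4-dichlorophenyl.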